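Acyl chain truncation in the anilide series

The source may hold more compounds than are shown below. What is called first, only, known or untested is meant among the compounds shown, and "the series" means these compounds.

Compound 1 `CCCCCCCCC(=O)N1c2ccccc2CCC1C(=O)Nc1ccccc1C(F)(F)F` carries an octylcarbonyl group on the shared core and a trifluoromethyl on an aromatic carbon of the anilide. Among the measured compounds shown here, in a functional assay on HCT-15 cells (Homo sapiens) for cytotoxicity, read by sulforhodamine B assay, with a stated time of 72 h (a lower number here means a stronger inhibitor of growth, a higher number a weaker inhibitor of growth), compound 1 gives 7700 nM, the lowest of the two numbers so far. Its nearest neighbour is compound 2 `CCCCCCCCC(=O)N1c2ccccc2CCC1C(=O)Nc1ccccc1O`, which in this assay gives 38400 nM; the step of a 5.0-fold higher number from compound 1 to compound 2 (0.70 log units; beyond the scatter) is the only measured one and concerns the anilide, not the acyl group. Compound 3 `CC(=O)N1c2ccccc2CCC1C(=O)Nc1ccccc1C(F)(F)F` differs from compound 1 by hydrogen in place of heptyl on a saturated chain carbon bound to a carbonyl carbon, that is octylcarbonyl to acetyl. For the measured compounds named here, no measured step covers this place, so neither direction nor size is anchored. Given that the whole heptyl is removed, a shift beyond the scatter is plausible, and the working expectation is a weaker inhibitor of growth: compound 3 is estimated at 20000 nM (range 4000 nM to 100000 nM). The expected step of a 2.6-fold higher number from compound 1 to compound 3 (0.41 log units; beyond the scatter) is therefore an increase, held loosely.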

Compound 3, concentration for 50% growth inhibition: > 80000 nM
Compound 3: a limit, no number; the forecaster's own chance of this, stated with the estimate: 15%; middle value at least 4.0-fold (0.60 log units) from the limit.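

In this assay compound 3 gives > 80000 nM, a limit of the assay and not a number. Changing octylcarbonyl to acetyl produces an at least 10-fold higher number from compound 1 to compound 3 (1.01 log units; beyond the scatter), so the acyl position, untouched by the earlier anilide step, has a large bearing on growth inhibition in this pair. The size of this step is bounded on one side only: the limit of > 80000 nM in this assay, at which 1 of the 3 values shown sits.

Only octylcarbonyl and acetyl are shown at this position, so it remains open how growth inhibition changes with an intermediate chain such as butyryl, a longer chain, or a chain ending in a carboxylic acid. On these data alone, it also remains open whether the same truncation has a comparable effect when the anilide carries hydroxy, as in compound 2, rather than trifluoromethyl.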